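The source may hold more compounds than are shown below. What is called first, only, known or untested is meant among the compounds shown, and "the series" means these compounds.

Measured so far:
- compound 1 `Cn1nc2c(=O)n(CC3(O)CCN(Cc4ccc(-c5ccco5)cc4Cl)CC3)cnc2c1-c1ccc(C(F)(F)F)cc1` — 530 nM in an assay on isolated protein for inhibition of ubiquitin carboxyl-terminal hydrolase 7 (Homo sapiens), with stated times of 30 min and 2 h; a higher number here means a weaker inhibitor, a lower number a stronger inhibitor
- compound 2 `Cn1nc2c(=O)n(CC3(O)CCN(Cc4ccc(-c5cccs5)cc4Cl)CC3)cnc2c1-c1ccc(CN)cc1` — 38.6 nM in this assay

Of the two values in hand, compound 2 gives the lower number, and the gap to compound 1 is beyond the scatter, so on these numbers compound 2 is the stronger inhibitor of the pair. The two compounds differ in more than one place, so nothing is attributed to any single change between them.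

Compound 3 `Cn1nc2c(=O)n(CC3(O)CCN(Cc4ccc(-c5ccc[nH]5)cc4Cl)CC3)cnc2c1-c1ccc(CN)cc1` is the unmeasured member of the series. Relative to compound 2 the change is 1H-pyrrol-2-yl in place of thiophen-2-yl on an aromatic carbon. The rest of the molecule, including the shared core, the chloro group and the large group, is unchanged.

For the measured compounds named here, no single-change step between measured compounds is available, so the expectation rests on compound 2 alone and on the modest nature of the swap, one five-membered aromatic ring with one hetero atom for another. In this assay the step from compound 2 to compound 3 is expected to be small, a 1.2-fold higher number from compound 2 to compound 3 (0.07 log units; within the scatter), with no direction claimed beyond the scatter. Compound 3 is estimated at 45 nM, within a range of 15 nM to 150 nM.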

Compound 3, half-maximal inhibitory concentration: 193 nM
The estimate for compound 3 lay 4.3-fold (0.63 log units) below the measured number, and the stated range ends below it.
By their numbers in this assay, from the lowest: compound 2; then compound 3; then compound 1.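

The thiophen-2-yl position, on an aromatic carbon para to a large group and meta to a chloro group, now has its first single-change reading: in this assay, 1H-pyrrol-2-yl in place of thiophen-2-yl gives a 5.0-fold higher number from compound 2 to compound 3 (0.70 log units; beyond the scatter). The position therefore distinguishes between these two five-membered aromatic rings, even though each has 1 hetero atom and the same heavy-atom count, with the rest of the molecule unchanged. The swap changes the hetero atom from sulfur to nitrogen and brings in a hydrogen-bond donor in place of a hydrogen-bond acceptor, but no measurement here separates these differences or explains the step.

Still open, going by these compounds, is how a 1-methylpyrrol-2-yl group, with a methyl on the ring nitrogen in place of its hydrogen, or a six-membered pyridine ring would read at this position. Compound 1 differs from compound 2 and compound 3 in more than one place, so it cannot settle either question.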